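Swapping an Imidazole Arm for a Short Ether Chain

The compounds below may be only part of what the source reports. "The series", "measured", "known", "first", "only" and "open" are said of these compounds alone.

Compound 3 `CCCNCc1nccn1Nc1nc(C)nc2c1c(C)nn2-c1ccc(OC)cc1C` sits in the middle of three compounds tested in a functional assay on CHO cells for antagonist activity at corticotropin-releasing factor receptor 1 (Homo sapiens), read by cAMP accumulation; a higher number here means a weaker inhibitor, a lower number a stronger inhibitor. Compound 3 gives 400 nM; compound 2 `CCCNCc1nc(Nc2nc(C)nc3c2c(C)nn3-c2ccc(OC)cc2C)no1` gives 124 nM, and compound 1 `CCCN(CC(=O)N(C)C)c1nc(C)nc2c1c(C)nn2-c1ccc(OC)cc1C` gives 1410 nM. Among the compounds with values here, the only measured step between compounds differing in one place, a 3.2-fold higher number from compound 2 to compound 3 (0.51 log units; beyond the scatter), shows that exchanging the group on the nitrogen on the aromatic ring produces a modest change. Compound 4 `CC[C@@H](COC)Nc1nc(C)nc2c1c(C)nn2-c1ccc(OC)cc1C` differs from compound 3 by 1-(methoxymethyl)propyl in place of 2-((propylamino)methyl)-1H-imidazol-1-yl on a nitrogen on an aromatic ring. Within the data shown here, no measured step covers this exact change; the gap between compound 1 and compound 2 shows that this position responds clearly to what is attached there. A step of a 5.0-fold lower number from compound 3 to compound 4 (0.70 log units; beyond the scatter) is therefore expected, toward a stronger inhibitor. Compound 4 is estimated at 80 nM, with a range from 20 nM to 400 nM.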

Compound 4, inhibition constant: 135 nM
Compound 4: middle estimate off by 1.7-fold (0.23 log units), on the low side; low and high end bracket the measured number.
By their numbers in this assay, from the lowest: compounds 2 and 4 (each within the scatter of the next); then compound 3; then compound 1.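

Replacing the imidazole arm with the smaller, ring-free 1-(methoxymethyl)propyl gives a 3.0-fold lower number from compound 3 to compound 4 (0.47 log units; beyond the scatter), so a ring on this nitrogen is not required for a lower number. Set against the oxadiazole arm, the same chain gives a 1.1-fold higher number from compound 2 to compound 4 (0.04 log units; within the scatter), so these two groups cannot be told apart here. Within the data shown here, exchanging ((dimethylcarbamoyl)methyl)(propyl)amino on the aromatic carbon for (1-(methoxymethyl)propyl)amino gives a 10-fold lower number from compound 1 to compound 4 (1.02 log units; beyond the scatter), the largest step so far.

Nothing shown explains these steps. Still open, going by these compounds, is how a hydroxyl in place of the methoxy, or the opposite stereocentre, would read.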